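The source may hold more compounds than are shown below. What is called first, only, known or untested is meant among the compounds shown, and "the series" means these compounds.

Compound 1 `c1ccc(-c2cccc3c2CCC3c2ncc[nH]2)nc1` is measured in a functional assay on CHO cells for agonist activity at Alpha-1A adrenergic receptor (Homo sapiens), read by FLIPR and calcium flux (a higher number here means a larger maximal response, a lower number a smaller maximal response), where compound 1 reaches 53%. Among the compounds reported with a single number it stands lowest; the nearest is compound 3 `CS(=O)(=O)Nc1c(Cl)ccc2c1CCCC2c1ncc[nH]1`, which gives 61% in this assay, a difference within the scatter, so no order between the two can be read from the numbers. Compound 2 `CS(=O)(=O)Nc1cccc2c1CCCC2c1ncc[nH]1` carries three entries in this assay, 47%; 79%; 79% (3 entries), and the spread among them (the several entries of compound 2 in this assay, 47%; 79%; 79% (3 entries)) shows how far repeated measurements of this kind can wander. The step to compound 4 `Cn1nccc1-c1cccc2c1CCC2c1ncc[nH]1` exchanges the substituent on the core of compound 1: 1-methyl-1H-pyrazol-5-yl in place of pyridin-2-yl on an aromatic carbon. For the measured compounds named here, no measured pair shows this exchange, and all three measured compounds lie in the same middle band of maximal response. The step of a number 3 percentage points lower from compound 1 to compound 4 (within the scatter) is therefore expected to stay within the scatter, in no clear direction. Compound 4 is estimated to give 50% in this assay, with a range from 30% to 72%.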

Compound 4, largest response reached (Emax), in percent of the reference or control that the assay uses: 58%
Compound 4: the middle estimate sits 8 percentage points below what was measured; the range from low to high includes it.
By their numbers in this assay, from the lowest: compounds 1, 4 and 3 (each within the scatter of the next).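

In this assay, for the compounds shown here, 1-methyl-1H-pyrazol-5-yl in place of pyridin-2-yl gives a number 5 percentage points higher from compound 1 to compound 4 (within the scatter), the first measured step at this aromatic carbon. The position therefore carries a five-membered aromatic ring with 2 hetero atoms as well as a six-membered aromatic ring with 1 hetero atom, with no readable change in maximal response, and both compounds remain in the same middle band. A step of this size cannot be separated from the spread of repeated measurements, as one compound shows: the several entries of compound 2 in this assay, 47%; 79%; 79% (3 entries)

The compounds shown leave open whether a group of another kind on this aromatic carbon, such as an amine, a carboxylic acid or a longer alkyl chain, would move the maximal response beyond the scatter. They also leave open whether the same exchange would read alike on the core of compound 2.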